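A Five-Membered Ring Replaces the Fluoropyridine

This account rests on a few compounds, and the source may have more. Where it says the series, first, only, none or still open, it means among the compounds named here.

Measured so far:
compound 1 `CCC(C)(C)Cc1c[nH]c(CCc2ccc(-n3ncnn3)cc2)n1`: 205 nM
compound 2 `CCC(C)(C)Cc1c[nH]c(CCc2ccc(-c3ccc(F)cn3)cc2)n1`: 19 nM

For the measured compounds named here, compound 2 stands lowest of the two numbers so far in an in vitro assay on CHO cells for displacement of a labelled ligand from Bombesin receptor subtype-3 (Homo sapiens), read by scintillation counting, with a stated time of 2 h; a higher number here means a weaker inhibitor, a lower number a stronger inhibitor; the only other compound, compound 1, sits above it, and the one measured step between them is an 11-fold lower number from compound 1 to compound 2 (1.03 log units; beyond the scatter). Compound 3 `CCC(C)(C)Cc1c[nH]c(CCc2ccc(-c3csnn3)cc2)n1` has not yet been measured. It differs from compound 2 in a single place: 1,2,3-thiadiazol-4-yl in place of 5-fluoropyridin-2-yl on an aromatic carbon. The measured step bears on this change only loosely. It shows that a six-membered 5-fluoropyridin-2-yl gave a much lower number than a five-membered 2H-tetrazol-2-yl, and the entering 1,2,3-thiadiazol-4-yl is again a five-membered aromatic ring with three hetero atoms, though not the same ring. The expected direction is therefore a higher number, of a size between the scatter and the measured step; the estimated step is a 4.2-fold higher number from compound 2 to compound 3 (0.62 log units; beyond the scatter). Compound 3 is thus expected to give about 80 nM in this assay, within a range from 25 nM to 250 nM.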

Compound 3, half-maximal inhibitory concentration: 45 nM
The estimate for compound 3 lay 1.8-fold (0.25 log units) above the measured number; measured number inside the range.
By their numbers in this assay, from the lowest: compound 2; then compound 3; then compound 1.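

In this assay, putting 1,2,3-thiadiazol-4-yl in place of 5-fluoropyridin-2-yl gives a 2.4-fold higher number from compound 2 to compound 3 (0.37 log units; beyond the scatter), so this position on the aromatic ring can hold a five-membered aromatic ring and still stay beyond the scatter on the favourable side of the tetrazole compound. That comparison is direct: exchanging 2H-tetrazol-2-yl for 1,2,3-thiadiazol-4-yl gives a 4.6-fold lower number from compound 1 to compound 3 (0.66 log units; beyond the scatter), which shows that two five-membered rings at the same place are not interchangeable and that ring size alone does not fix the number, while the six-membered 5-fluoropyridin-2-yl still holds the lowest number of the three. No measurement shown here accounts for these differences, so the reason for the order remains unexplained.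

The three compounds cannot separate the contribution of ring size from that of the kind and number of hetero atoms, and a plain phenyl ring or an unsubstituted pyridin-2-yl would be needed to test this. On these data alone, whether a non-aromatic group at this place, such as an amine or a carboxylic acid, would fit the same order also remains open.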